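The source may report more compounds than this note shows. Statements on the series, on what has been measured and on what is new or still open speak of the compounds shown alone.

In a functional assay on MT4 cells (Homo sapiens) for antiproliferative activity, read by MTT assay, with a stated time of 96 h (a higher number here means a weaker inhibitor, a lower number a stronger inhibitor), three compounds built on a shared core have been measured. Compound 1 `O=C1C2=C(C(=O)c3ncccc31)C1(CS2)NC(=O)N(c2ccc(Cl)cc2)C1=O`, with chloro on an aromatic carbon, gives 10 nM. Compound 2 `CCCCCc1ccc(N2C(=O)NC3(CSC4=C3C(=O)c3ncccc3C4=O)C2=O)cc1`, with pentyl in that place, gives 190 nM, the higher of these two numbers and so the weaker result of the pair. Compound 3 `O=C1NC(=O)C2(CSC3=C2C(=O)c2ncccc2C3=O)N1` gives 130 nM; 120 nM; 130 nM (3 entries), and the several entries of compound 3 in this assay, 130 nM; 120 nM; 130 nM (3 entries) show how closely repeat readings can agree.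

Compound 4 `CCCCc1ccc(N2C(=O)NC3(CSC4=C3C(=O)c3ncccc3C4=O)C2=O)cc1` has not yet been measured. Its difference from compound 2 is small: hydrogen in place of methyl on a saturated chain carbon, four bonds along the chain from an aromatic carbon. In words, hydrogen stands in place of methyl on a saturated chain carbon, four bonds along the chain from an aromatic carbon, so the pentyl chain becomes butyl.

Going by the values given here, only one measured step bears on this change, a 19-fold higher number from compound 1 to compound 2 (1.28 log units; beyond the scatter), and it is large. Among the compounds with values here, that step replaced the entire group, however, whereas here only the end methyl leaves, and no measured pair yet shows what shortening a chain does. A much smaller step is therefore expected, with at most a slight lean towards a lower number. The expected change, a 1.5-fold lower number from compound 2 to compound 4 (0.16 log units; within the scatter), stays within the usual scatter. The estimate for compound 4 is 130 nM, with an expected range from 45 nM to 350 nM.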

Compound 4, half-maximal inhibitory concentration: 200 nM
Beside the measured number, compound 4's estimate is 1.5-fold (0.19 log units) below it; low and high end bracket the measured number.
By their numbers in this assay, from the lowest: compound 1; then compounds 2 and 4 (each within the scatter of the next).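

In this assay the end methyl of the chain carries no visible weight, with a 1.1-fold higher number from compound 2 to compound 4 (0.02 log units; within the scatter), so pentyl and butyl cannot be told apart at this place. The large gap to the chloro group remains after the chain is shortened, with a 20-fold higher number from compound 1 to compound 4 (1.30 log units; beyond the scatter), much like the earlier 19-fold higher number from compound 1 to compound 2 (1.28 log units; beyond the scatter), so among these three compounds both chains stand clearly apart from chloro. Repeat readings can sit very close together, and a step this small is best read as no change at all: the several entries of compound 3 in this assay, 130 nM; 120 nM; 130 nM (3 entries)

Only two chain lengths are shown, so propyl, ethyl or methyl, or a longer chain such as hexyl, would be needed to tell whether the numbers stay flat or at some length move towards compound 1 at 10 nM. As far as these compounds go, whether chloro itself is what sets compound 1 apart also remains open, and an amine, a methoxy group or a carboxylic acid on that same aromatic carbon would begin to answer this.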